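Swapping a dichlorophenyl for a methoxyphenyl on the ketone

The source may report more compounds than this note shows. Statements on the series, on what has been measured and on what is new or still open speak of the compounds shown alone.

Three compounds share one core. In a functional assay on K562 cells (Homo sapiens) for cytotoxicity, read by sulforhodamine B assay, with a stated time of 48 h, tested at 100 uM (a lower number here means a stronger effect, a higher number a weaker effect of the compound at the concentration tested), compound 1 `COc1ccc(-c2cc(/C=C/C(=O)c3ccc(N)cc3)[nH]n2)cc1` gives -60%. Compound 2 `COc1cc(-c2cc(/C=C/C(=O)c3ccc(Cl)c(Cl)c3)[nH]n2)cc(OC)c1OC` gives -7%, and compound 3 `COc1ccc(C(=O)/C=C/c2cc(-c3cc(OC)c(OC)c(OC)c3)n[nH]2)cc1OC` gives -15%. On these numbers compound 2 and compound 3 sit within the usual scatter of each other, while compound 1 lies far below both of them. Within the data shown here, the only measured step that bears on the question here is a number 8 percentage points lower from compound 2 to compound 3 (within the scatter). Compound 4 `COc1ccc(C(=O)/C=C/c2cc(-c3cc(OC)c(OC)c(OC)c3)n[nH]2)cc1` differs from compound 2 in a closely related way: 4-methoxyphenyl in place of 3,4-dichlorophenyl on a carbonyl carbon A step of similar size is expected, that is none beyond the scatter, so the estimated step is a number 5 percentage points lower from compound 2 to compound 4 (within the scatter). Compound 4 is therefore expected to give -12%, with a range from -35% to 10%.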

Compound 4, a percentage reported as activity, at one concentration (the size of the read-out at that concentration, not a potency): 1%
The estimate for compound 4 lay 13 percentage points below the measured number, and the stated range covers the measured number.
By their numbers in this assay, from the lowest: compound 1; then compounds 3, 2 and 4 (each within the scatter of the next, the first and the last beyond it).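

In this assay, 4-methoxyphenyl in place of 3,4-dichlorophenyl on a carbonyl carbon gives a number 8 percentage points higher from compound 2 to compound 4 (within the scatter), so this second swap on the ketone also produces no change beyond the scatter. Among these compounds, the ring is not wholly insensitive, though: hydrogen in place of methoxy on an aromatic carbon gives a number 16 percentage points higher from compound 3 to compound 4 (beyond the scatter), a modest step and the only one here at this ring beyond the scatter. Nothing available explains this difference.

The compounds shown leave open how a carboxylic acid or a longer alkoxy chain on this ring would read. A single concentration also cannot show whether potency shifts.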